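Ring heteroatom swap on the thiocarbonyl: compound 2 to 3

The compounds below may be only part of what the source reports. "The series", "measured", "known", "first", "only" and "open" are said of these compounds alone.

Measured so far:
compound 1 `N/C(=N\NC(=S)N1CCOCC1)c1ccccn1` — 29.2%
compound 2 `N/C(=N\NC(=S)N1CCSCC1)c1ccccn1` — 31.7%

In a functional assay on A-431 cells (Homo sapiens) for cytotoxicity, read by MTT assay, with a stated time of 72 h, tested at 1 uM (on this read-out lower numbers stand for less inhibition of growth and higher numbers for more inhibition of growth at the one concentration tested), compound 2 gives 31.7% and compound 1 gives 29.2%. Going by the values given here, the one measured step, a number 2.5 percentage points higher from compound 1 to compound 2 (within the scatter), lies within the scatter, so compound 2 is not set apart from compound 1 on these numbers.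

Compound 3 `N/C(=N\NC(=S)N1CCCCC1)c1ccccn1` differs from compound 2 by piperidin-1-yl in place of thiomorpholin-4-yl on a thiocarbonyl carbon. Among the compounds with values here, the only step that bears on exchanging the six-membered ring on the thiocarbonyl carbon is a number 2.5 percentage points higher from compound 1 to compound 2 (within the scatter), which was within the scatter; no step beyond the scatter is therefore expected, a number 0.3 percentage points higher from compound 2 to compound 3 (within the scatter). For compound 3 the estimate is 32%, within 22% to 42%.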

Compound 3, percent growth inhibition at one concentration: 24.4%
Compound 3: middle estimate off by 7.6 percentage points, on the high side; measured number inside the range.
By their numbers in this assay, from the lowest: compounds 3, 1 and 2 (each within the scatter of the next).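

Piperidin-1-yl on the thiocarbonyl carbon carries no ring hetero atom other than the nitrogen, yet in this assay the exchange gives a number 7.3 percentage points lower from compound 2 to compound 3 (within the scatter) and a number 4.8 percentage points lower from compound 1 to compound 3 (within the scatter). The three six-membered rings are therefore not set apart at this position, with or without the second ring hetero atom. No measurement available here accounts for the values.

Open, on these data alone, is whether a piperazin-1-yl ring, with its further ring amine, or an open-chain dimethylamino group at this carbon would stay in the same range.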